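A few compounds are considered here, and "the series" means these few. Any claim that something is new, unique, unknown or untested is made for them only; others in the source may bear on it.

Measured compounds:

- Compound 1 `CC(=O)Nc1ccc(-n2nncc2CN2C(=O)C3(C(C#N)=C(N)Oc4c(N)cc5nc6ccccc6nc5c43)c3ccccc32)cc1`. In a functional assay on MCF7 cells (Homo sapiens) for antiproliferative activity, read by MTT assay, with a stated time of 48 h (a lower number here means a stronger inhibitor, a higher number a weaker inhibitor), compound 1 gives > 50000 nM, which is a limit of the assay rather than a number.
- Compound 2 `N#CC1=C(N)Oc2c(N)cc3nc4ccccc4nc3c2C12C(=O)N(Cc1cnnn1-c1c(F)cccc1F)c1ccccc12`. In this assay compound 2 gives > 50000 nM, again a limit of the assay.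
- Compound 3 `Cc1ccc(-n2nncc2CN2C(=O)C3(C(C#N)=C(N)Oc4c(N)cc5nc6ccccc6nc5c43)c3ccccc32)cc1Cl`. In this assay compound 3 gives > 50000 nM, also a limit of the assay.

Compound 3 therefore stands nowhere in particular among these three: all of them sit at the same limit, (the limit of > 50000 nM in this assay, at which 3 of the 3 values shown sit), so none can be ranked against another. The change to the unmeasured compound 4 `COc1cc(-n2nncc2CN2C(=O)C3(C(C#N)=C(N)Oc4c(N)cc5nc6ccccc6nc5c43)c3ccccc32)c(OC)cc1Cl` is 4-chloro-2,5-dimethoxyphenyl in place of 3-chloro-4-methylphenyl on an aromatic nitrogen. The measured steps that bear on it are the three exchanges of the group on that same aromatic nitrogen: a step that the two limits leave unreadable from compound 1 to compound 2, a step that the two limits leave unreadable from compound 1 to compound 3 and a step that the two limits leave unreadable from compound 2 to compound 3. Each of them runs between two limits, so no size can be read from any of them. With three such exchanges leaving every value at the limit, the step in this assay is expected to be a number no higher from compound 3 to compound 4 (the limit leaves the size open), that is, nothing readable beyond the scatter. Compound 4 is accordingly estimated at 50000 nM, with a range from 20000 nM to 100000 nM, and most probably the assay will once more report only a limit.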

Compound 4, half-maximal inhibitory concentration: > 50000 nM
Compound 4: a limit, no number; the forecaster's own chance of this, stated with the estimate: 85%; the middle value sits exactly at the limit.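

In this assay compound 4 gives > 50000 nM, which is a limit of the assay and not a number. For the compounds shown here, its steps to compound 1, compound 2 and compound 3 therefore cannot be read, and no compound can be ranked against another: the limit of > 50000 nM in this assay, at which 4 of the 4 values shown sit. The compounds shown leave open how strongly any of them acts, and whether the group on that aromatic nitrogen matters at all.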